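The compounds below may be only part of what the source reports. "The series", "measured", "known", "first", "only" and "open" are said of these compounds alone.

Measured compounds, with their values in a functional assay on CHO cells with adenosine receptor A1 (Homo sapiens) as the target, read by cAMP accumulation and immunoassay, with a stated time of 6 min, tested at 0.1 uM; a higher number here means a weaker effect of the compound at the concentration tested, a lower number a stronger effect:

compound 1, `Nc1scc(CN2CCN(c3cccnc3)CC2)c1C(=O)c1ccc(Cl)cc1`: 3.4%
compound 2, `Nc1scc(CN2CCN(c3ccncc3)CC2)c1C(=O)c1ccc(Cl)cc1`: 1.4%
compound 3, `Nc1scc(CN2CCN(c3cccc4ccccc34)CC2)c1C(=O)c1ccc(Cl)cc1`: 0%

All three share one core and differ only in the aryl group on the amine nitrogen in the ring. Compound 3 carries the smallest number of the three, but the steps of a number 3.4 percentage points lower from compound 1 to compound 3 (within the scatter) and a number 1.4 percentage points lower from compound 2 to compound 3 (within the scatter) are both within the scatter, as is a number 2 percentage points lower from compound 1 to compound 2 (within the scatter), so the three cannot be told apart in this assay ; each sits near the floor of the read-out.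

Compound 4, `Nc1scc(CN2CCN(c3c(F)cc(F)cc3F)CC2)c1C(=O)c1ccc(Cl)cc1`, is not yet measured. It differs from compound 3 by 2,4,6-trifluorophenyl in place of naphthalen-1-yl on an amine nitrogen in a ring. Every measured step alters the same aryl group on the ring nitrogen, so all three bear on this change, and none of them moved the number beyond the scatter. Nothing in the measured set therefore points to a step in either direction for compound 4; a further exchange of the aryl group is expected to leave the number near where compound 3 lies.

Compound 4 is expected at 2%, between 0% and 9%. The expected step is a number 2 percentage points higher from compound 3 to compound 4 (within the scatter), within the scatter.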

Compound 4, a percentage reported as activity, at one concentration (the size of the read-out at that concentration, not a potency): -3.9%
Compound 4: the middle estimate sits 5.9 percentage points above what was measured; the whole stated range lies above it.
By their numbers in this assay, from the lowest: compounds 4, 3, 2 and 1 (each within the scatter of the next).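

In this assay, replacing any of the three earlier aryl groups with 2,4,6-trifluorophenyl on the amine nitrogen in the ring leaves every step within the scatter: a number 3.9 percentage points lower from compound 3 to compound 4 (within the scatter), a number 5.3 percentage points lower from compound 2 to compound 4 (within the scatter), and a number 7.3 percentage points lower from compound 1 to compound 4 (within the scatter). Going by these compounds alone, the earlier compounds covered only two pyridinyl groups and naphthalen-1-yl, so compound 4 adds a fluorine-bearing carbon ring to the groups at this position whose numbers lie within the scatter of one another, and compound 4, at -3.9%, cannot be told apart from the others. Nothing available explains why the number holds across these groups.

With all four compounds near the floor at a single concentration, this read-out leaves any ranking of the aryl groups open, and a full concentration-response series would be needed to settle whether they differ at all. On these data alone, it also remains open whether a non-aromatic group on the same nitrogen, such as cyclohexyl or acetyl, or a carboxylic acid on the aryl ring, would move the number beyond the scatter.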